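The source may hold more compounds than are shown below. What is called first, only, known or untested is meant among the compounds shown, and "the series" means these compounds.

Measured so far in an assay for inhibition of inositol hexakisphosphate kinase 3 (Homo sapiens), read by colorimetric assay, coupled enzyme assay and malachite green, with a stated time of 120 min, in the presence of a further agent that is not named here; a higher number here means a weaker inhibitor, a lower number a stronger inhibitor:
compound 1 `O=C(O)c1ccc2noc(-c3ccc(-c4ccncc4)cc3)c2c1` gives 670 nM;
compound 2 `O=C(O)c1ccc2noc(-c3ccc(Oc4ccccc4)cc3)c2c1` gives 550 nM;
compound 3 `O=C(O)c1ccc2noc(-c3ccc(Oc4ncc(Cl)cc4Cl)cc3)c2c1` gives 2250 nM.

Compound 3 gives the highest number of the three: the step of a 3.4-fold higher number from compound 1 to compound 3 (0.53 log units; beyond the scatter) and the step of a 4.1-fold higher number from compound 2 to compound 3 (0.61 log units; beyond the scatter) both lie beyond the scatter, while a 1.2-fold lower number from compound 1 to compound 2 (0.09 log units; within the scatter) does not. Compound 4 `O=C(O)c1ccc2noc(-c3ccc(NC(=O)C4CCCC4)cc3)c2c1` differs from compound 3 by (cyclopentylcarbonyl)amino in place of (3,5-dichloropyridin-2-yl)oxy on an aromatic carbon. Among the compounds with values here, no measured step introduces an amide at this position, so only the two steps into compound 3 bear on it, and they show that the other two groups at this carbon gave lower numbers than the (3,5-dichloropyridin-2-yl)oxy group. A downward step of about that size is therefore expected, a 2.8-fold lower number from compound 3 to compound 4 (0.45 log units; beyond the scatter). Compound 4 is estimated at 800 nM, within a range of 250 nM to 2500 nM.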

Compound 4, half-maximal inhibitory concentration: 240 nM
Compound 4: the middle estimate sits 3.3-fold (0.52 log units) above what was measured; the whole stated range lies above it.
By their numbers in this assay, from the lowest: compound 4; then compounds 2 and 1 (each within the scatter of the next); then compound 3.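

The steps of a 9.4-fold lower number from compound 3 to compound 4 (0.97 log units; beyond the scatter) and a 2.3-fold lower number from compound 2 to compound 4 (0.36 log units; beyond the scatter) and a 2.8-fold lower number from compound 1 to compound 4 (0.45 log units; beyond the scatter) all lie beyond the scatter and make compound 4 the strongest inhibitor of the four. At this carbon, then, a low number does not require the six-membered aromatic ring carried by the groups in compounds 1 to 3: (cyclopentylcarbonyl)amino, with its five-membered non-aromatic ring, does better than all three. No evidence given here accounts for this change.

Which part of the (cyclopentylcarbonyl)amino group matters remains open. The compounds shown do not separate the amide hydrogen from the cyclopentyl ring, and they include no cyclohexyl ring, open alkyl chain or methyl on the amide nitrogen.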